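Swapping the Benzyl Ring on a Bis(trifluoromethyl)sulfonamide Chain

The source may report more compounds than this note shows. Statements on the series, on what has been measured and on what is new or still open speak of the compounds shown alone.

Three compounds share one core and differ only in the aromatic ring attached to a saturated chain carbon bound to an amine nitrogen. Compound 1 `O=S(=O)(NCCCNCc1ccccc1Cl)c1cc(C(F)(F)F)cc(C(F)(F)F)c1` carries a 2-chlorophenyl there, compound 2 `O=S(=O)(NCCCNCc1ccc(Cl)c(C(F)(F)F)c1)c1cc(C(F)(F)F)cc(C(F)(F)F)c1` a 4-chloro-3-(trifluoromethyl)phenyl, and compound 3 `O=S(=O)(NCCCNCc1ccccc1)c1cc(C(F)(F)F)cc(C(F)(F)F)c1` a plain phenyl. In a functional assay on ASPC1 cells (Homo sapiens) for inhibition, read by MTT assay, with a stated time of 72 h (on this read-out lower numbers stand for stronger inhibition of growth and higher numbers for weaker inhibition of growth), compound 1 gives 13000 nM, compound 2 gives 9600 nM and compound 3 gives 13000 nM. Compound 1 stands level with compound 3 at the digits shown, the two together the highest of the three numbers, with compound 2 the furthest from it. The steps are small: a 1.4-fold lower number from compound 1 to compound 2 (0.13 log units; within the scatter), no change at the digits printed from compound 1 to compound 3 (within the scatter) and a 1.4-fold higher number from compound 2 to compound 3 (0.13 log units; within the scatter), each within the scatter.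

Compound 4 `COc1cccc(CNCCCNS(=O)(=O)c2cc(C(F)(F)F)cc(C(F)(F)F)c2)c1` keeps the core and places a new ring on the same chain carbon: 3-methoxyphenyl in place of 2-chlorophenyl on a saturated chain carbon bound to an amine nitrogen. The measured steps that bear on this are the ring exchanges from compound 1 to compound 2 and from compound 1 to compound 3, neither of which moved the number beyond the scatter. On that basis no shift beyond the scatter is expected in this assay for compound 4, in either direction, so the estimated step is a 1.1-fold lower number from compound 1 to compound 4 (0.03 log units; within the scatter). Compound 4 is expected to give 12000 nM, with a range from 6000 nM to 25000 nM.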

Compound 4, concentration for 50% growth inhibition: 3800 nM
Compound 4: the middle estimate sits 3.2-fold (0.50 log units) above what was measured; the measured number lies below the stated range.
By their numbers in this assay, from the lowest: compound 4; then compounds 2, 1 and 3 (each within the scatter of the next).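

Unlike the earlier ring exchanges, which all stayed within the scatter, the 3-methoxyphenyl ring of compound 4 moves the number beyond the scatter in this assay against each of the other three compounds (a 3.4-fold lower number from compound 1 to compound 4 (0.53 log units; beyond the scatter); a 3.4-fold lower number from compound 3 to compound 4 (0.53 log units; beyond the scatter); a 2.5-fold lower number from compound 2 to compound 4 (0.40 log units; beyond the scatter)). The step from compound 3 is the cleanest reading, since a single methoxy in place of hydrogen on an aromatic carbon of the plain phenyl ring is enough to strengthen growth inhibition, so this position is not as indifferent to its ring as the first three compounds suggested. Nothing measured here explains why the methoxy-bearing ring does better.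

The compounds shown leave open whether the gain belongs to the methoxy group itself or to where it sits on the ring, which a 4-methoxyphenyl ring would test, and whether the oxygen matters, which a 3-methylphenyl or 3-hydroxyphenyl ring would test. They also leave open whether the same gain would hold on a longer chain in the shared core.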